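Methyl added on the fused core of compound 1

The source may report more compounds than this note shows. Statements on the series, on what has been measured and on what is new or still open speak of the compounds shown alone.

Compound 1 `CNc1nncc2cncn12` is known in a functional assay for inhibition, with Homo sapiens as the target (a higher number here means a weaker inhibitor, a lower number a stronger inhibitor), only by a limit: compound 1 gives > 48000 nM, which is a limit of the assay and not a number. Compound 2 `c1nc(Nc2nncc3cncn23)n[nH]1` gives 46000 nM in this assay. Compound 3 `Sc1nncc2cncn12` in this assay gives > 48000 nM, again a limit and not a number. The two measured steps are an at least 1.0-fold lower number from compound 1 to compound 2 (0.01 log units; that floor lies within the scatter) and a step that the two limits leave unreadable from compound 1 to compound 3; the second cannot be sized because of the limit of > 48000 nM in this assay, at which 2 of the 3 values shown sit. Both steps alter the methylamino substituent, so neither bears directly on compound 4 `CNc1nncc2c(C)ncn12`, which differs from compound 1 by methyl in place of hydrogen on an aromatic carbon. With compound 1 itself only bounded, no step beyond the scatter can be read from the numbers, and the expected step is a step that the limit leaves unreadable from compound 1 to compound 4, with the assay most likely again reporting only a limit. Compound 4 is therefore estimated at 60000 nM, with an expected range from 20000 nM to 200000 nM.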

Compound 4, half-maximal inhibitory concentration: > 48000 nM
Compound 4 gave a limit, no number (the forecaster's own chance of this, stated with the estimate: 75%); the middle value lies beyond the limit too.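

In this assay compound 4 gives > 48000 nM as a limit and not a number, and compound 1 also stands only as a limit, so no step from compound 1 to compound 4 can be read: the limit of > 48000 nM in this assay, at which 3 of the 4 values shown sit.
The compounds shown leave open what methyl in place of hydrogen on an aromatic carbon does to inhibition.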